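Compound 4: nitro returns, with chloro added

The compounds below may be only part of what the source reports. "The series", "measured", "known", "first", "only" and "open" are said of these compounds alone.

compound 1 `Fc1ccc(C(CCCCOCc2ccc(Oc3ccc(Cl)cc3)cc2)c2ccc(F)cc2)cc1`: > 20000 nM
compound 2 `O=C(NCCCCC(c1ccc(F)cc1)c1ccc(F)cc1)Nc1ccc([N+](=O)[O-])cc1`: 6470 nM
compound 3 `O=C(NCCCCC(c1ccc(F)cc1)c1ccc(F)cc1)Nc1ccc(C(F)(F)F)cc1`: 2780 nM

These values come from a functional assay on MDA-MB-231 cells (Homo sapiens) for cytotoxicity, read by MTT assay, with a stated time of 48 h; on this read-out lower numbers stand for stronger inhibition and higher numbers for weaker inhibition. Compound 1 gives > 20000 nM, which is a limit of the assay and not a number. Of the two actual numbers, the lower belongs to compound 3 at 2780 nM, and the nearest neighbour is compound 2 at 6470 nM.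

The next compound is compound 4 `O=C(NCCCCC(c1ccc(F)cc1)c1ccc(F)cc1)Nc1ccc([N+](=O)[O-])c(Cl)c1`, with 3-chloro-4-nitrophenyl in place of 4-(trifluoromethyl)phenyl on an amide-type nitrogen. Within the data shown here, one measured step bears on this change: a 2.3-fold lower number from compound 2 to compound 3 (0.37 log units; beyond the scatter), with trifluoromethyl in place of nitro. That step was modest and beyond the scatter. The new group brings nitro back, so some movement towards a higher number is expected. Among the measured compounds shown here, no measured step shows what the added chloro does, which leaves the size uncertain. A small rise is therefore expected in this assay, estimated as a 1.6-fold higher number from compound 3 to compound 4 (0.21 log units; within the scatter). Compound 4 is expected at about 4500 nM, within an estimated range of 1800 nM to 11000 nM.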

Compound 4, half-maximal inhibitory concentration: 3470 nM
The estimate for compound 4 lay 1.3-fold (0.11 log units) above the measured number; measured number inside the range.
By their numbers in this assay, from the lowest: compounds 3, 4 and 2 (each within the scatter of the next, the first and the last beyond it). At a limit, above all of these: compound 1.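

In this assay, chloro in place of hydrogen on an aromatic carbon gives a 1.9-fold lower number from compound 2 to compound 4 (0.27 log units; within the scatter), so at this position the effect of adding chloro to the nitro-bearing group cannot be told from the usual scatter. Putting 3-chloro-4-nitrophenyl in place of 4-(trifluoromethyl)phenyl on the amide-type nitrogen gives a 1.2-fold higher number from compound 3 to compound 4 (0.10 log units; within the scatter), so these two groups cannot be told apart in this read-out, although the step between compound 2 and compound 3 lies beyond the scatter. Nothing among the measurements shown offers a reason for these results.

The compounds shown leave open whether chloro without nitro on this aromatic ring, or an amine or a carboxylic acid there, would move the number beyond the scatter. They also leave open what a longer chain in the shared core would do.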